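A few compounds are considered here, and "the series" means these few. Any claim that something is new, unique, unknown or untested is made for them only; others in the source may bear on it.

Measured compounds:
compound 1 `O=C(O)Cc1ccc(-c2ccc(CN3CC(=O)N(c4ccccc4)C3=O)cc2)cc1` — 2.18
compound 2 `O=C1CN(Cc2ccc(-c3ccccc3)cc2)C(=O)N1c1ccccc1` — 6.24

Among the measured compounds shown here, in a physicochemical assay for lipophilicity, read by HPLC, at pH 7.4 (on this read-out higher numbers stand for higher lipophilicity and lower numbers for lower lipophilicity), compound 1 gives 2.18, the lower of the two numbers measured so far. For the measured compounds named here, compound 2 `O=C1CN(Cc2ccc(-c3ccccc3)cc2)C(=O)N1c1ccccc1`, with hydrogen in place of carboxymethyl on an aromatic carbon, gives 6.24; the step of a number 4.06 log units higher from compound 1 to compound 2 (beyond the scatter) is the only measured step.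

Compound 3 `O=C(O)Cc1ccc(-c2ccc(CN3CC(=O)N(C4CCCCC4)C3=O)cc2)cc1` is not yet measured. It differs from compound 1 by cyclohexyl in place of phenyl on an amide-type nitrogen in a ring. Going by the values given here, no measured step covers this exchange: the one step known, from compound 1 to compound 2, concerns the carboxymethyl group, and compound 3 keeps that group, so this step does not apply to the change to compound 3. Only the direction can be taken from the kind of exchange. A shift upward in this assay is expected, smaller than the step from compound 1 to compound 2 and of modest size, with the step of a number 0.62 log units higher from compound 1 to compound 3 (beyond the scatter) as the working figure. For compound 3 the estimate in this assay is 2.8, with a range from 2.2 to 3.4.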

Compound 3, distribution coefficient: 1.12
Compound 3: the middle estimate sits 1.68 log units above what was measured; the whole stated range lies above it.
By their numbers in this assay, from the lowest: compound 3; then compound 1; then compound 2.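

Among the compounds shown here, the amide-type nitrogen in a ring proves to be a position that moves the number on its own in this assay, with the carboxymethyl group kept in place: cyclohexyl in place of phenyl gives a number 1.06 log units lower from compound 1 to compound 3 (beyond the scatter), whereas the only earlier step concerned the carboxymethyl group. The two groups match in heavy atoms, in carbon-only composition, in hydrogen-bond donors and acceptors and in net charge, and the printed difference between them is an aromatic ring against a non-aromatic ring, so a change that leaves all those counts equal still carries a large step at this place. Nothing at hand accounts for the direction or the size of this step.

The compounds shown leave open whether the exchange gives a step of the same direction and size when hydrogen stands in place of carboxymethyl, as in compound 2. They also leave open whether other groups on this nitrogen, such as cyclopentyl, an open hexyl chain or a phenyl ring carrying an amine, would fall nearer to compound 3 or to compound 1.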